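Halogen exchange on the benzyl group of the shared core

This account rests on a few compounds, and the source may have more. Where it says the series, first, only, none or still open, it means among the compounds named here.

Measured so far:
compound 1 `Cc1cccc(Cl)c1CC1CN/C(=N\N(C)C)CN(CC(=O)Nc2cccc(-c3cnn(C)c3)c2)C1=O` – 1600 nM
compound 2 `Cc1cccc(F)c1CC1CN/C(=N\N(C)C)CN(CC(=O)Nc2cccc(-c3cnn(C)c3)c2)C1=O` – 7700 nM

In an assay on isolated protein for inhibition of kallikrein-7 (Mus musculus), read by fluorescence, with stated times of 10 min and 30 min (a lower number here means a stronger inhibitor, a higher number a weaker inhibitor), compound 2 gives 7700 nM, the higher of the two numbers shown; its nearest neighbour is compound 1, which gives 1600 nM. Compound 3 `CN(C)/N=C1/CN(CC(=O)Nc2cccc(-c3cnn(C)c3)c2)C(=O)C(Cc2c(F)cccc2Cl)CN1` differs from compound 2 by chloro in place of methyl on an aromatic carbon. Going by the values given here, the one measured step, a 4.8-fold higher number from compound 1 to compound 2 (0.68 log units; beyond the scatter), involved the same chloro-fluoro pair on this ring and was modest. Compound 3 carries both a chloro and a fluoro there, so a move back toward compound 1 is expected. Compound 3 is therefore expected at 2500 nM (range 900 nM to 7000 nM), a step of a 3.1-fold lower number from compound 2 to compound 3 (0.49 log units; beyond the scatter).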

Compound 3, half-maximal inhibitory concentration: 6000 nM
Beside the measured number, compound 3's estimate is 2.4-fold (0.38 log units) below it, within the range that was stated.
By their numbers in this assay, from the lowest: compound 1; then compounds 3 and 2 (each within the scatter of the next).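

In this assay, with fluoro held on the ring, a 1.3-fold lower number from compound 2 to compound 3 (0.11 log units; within the scatter), so this position does not separate chloro from methyl in that setting. With chloro held, a 3.8-fold higher number from compound 1 to compound 3 (0.57 log units; beyond the scatter), so here the methyl-to-fluoro change does register. Among these three compounds, only compound 1, the one without fluoro, stands apart from the other two, and no measured evidence accounts for this.

Open, going by these compounds, is how a bromo or a methoxy at this position would read, and whether a second chloro in place of the fluoro would match compound 1.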